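A few compounds are considered here, and "the series" means these few. Any claim that something is new, unique, unknown or untested is made for them only; others in the source may bear on it.

Measured so far in a functional assay on CHO cells for agonist activity at Melanocyte-stimulating hormone receptor (Homo sapiens), read by a luciferase reporter, with a stated time of 4 h; on this read-out higher numbers stand for an effect only at larger amounts of compound and lower numbers for an effect already at smaller amounts:
compound 1 `COc1ccc(N(C(=O)CN2C=CN(c3ccccc3)C(=O)C(Cc3n[nH]c4ccccc34)C2=O)C(C)C)cc1` gives 29.5 nM
compound 2 `CC(C)N(C(=O)CN1C=CN(c2ccccc2)C(=O)[C@H](Cc2n[nH]c3ccccc23)C1=O)c1ccccc1` gives 295 nM
compound 3 `O=C1C(Cc2n[nH]c3ccccc23)C(=O)N(c2ccccc2)C=CN1CC(=O)N1CCCCc2ccccc21` gives 1.59 nM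

Compound 3 has the lowest number of the three, with compound 1 the nearest and compound 2 the furthest away. Compound 4 `CC(C)N(C(=O)CN1C=CN(c2ccccc2)C(=O)C(Cc2n[nH]c3ccccc23)C1=O)c1ccccc1` differs from compound 3 in one place: a group of 10 heavy atoms (9 carbon, 1 nitrogen; one six-membered aromatic ring of carbon only) in place of a group of 11 heavy atoms (10 carbon, 1 nitrogen; one six-membered aromatic ring of carbon only, one seven-membered non-aromatic ring with 1 hetero atom), on a carbonyl carbon. For the measured compounds named here, the only measured step at this carbonyl carbon is a 19-fold lower number from compound 1 to compound 3 (1.27 log units; beyond the scatter), and the new change moves back toward a group of that kind, so a large rise in the number is expected. Compound 4 also has the same atoms and bonds as compound 2, differing only in that its stereocentre is left unspecified, and compound 2 gives 295 nM. Compound 4 is therefore expected to give about 250 nM, within 80 nM to 800 nM, an expected step of a 160-fold higher number from compound 3 to compound 4 (2.20 log units; beyond the scatter).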

Compound 4, half-maximal effective concentration: 708 nM
For compound 4 the middle estimate is 2.8-fold (0.45 log units) below the measured one; the measured number falls inside the stated range.
By their numbers in this assay, from the lowest: compound 3; then compound 1; then compound 2; then compound 4.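

In this assay, isopropyl(phenyl)amino in place of the seven-membered ring group on this carbonyl carbon gives a 450-fold higher number from compound 3 to compound 4 (2.65 log units; beyond the scatter), the largest step yet. Methoxy on the aromatic carbon now has its own measured step, since hydrogen in its place gives a 24-fold higher number from compound 1 to compound 4 (1.38 log units; beyond the scatter). The step of a 2.4-fold higher number from compound 2 to compound 4 (0.38 log units; beyond the scatter) is modest, and all that separates these two compounds is this: the fact that one of compounds 2 and 4 is drawn with a defined configuration and the other without, at the place where they differ

Open, on these data alone, is how the same compound drawn S would compare. Also open, as far as these compounds go, is what a piperidine or a dimethylamino group would do on this carbonyl carbon.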